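The source may hold more compounds than are shown below. What is called first, only, known or untested is meant among the compounds shown, and "the series" means these compounds.

Working notes on the series in a functional assay on MG-63 cells (Homo sapiens) for inhibition, read by CCK-8 assay, with a stated time of 72 h, tested at 1 uM; on this read-out higher numbers stand for more inhibition at the one concentration tested (going by the name of the read-out) and lower numbers for less inhibition.

Compound 1 `O=C(NCCCCc1ccccc1)c1cccc(C2SCC(=O)N2c2ccccc2)c1` gives 89% in this assay. Compound 2 `O=C(NCCCCc1ccccc1)c1cccc(C2SCC(=O)N2c2cccc(F)c2)c1` gives 92%. Compound 3 `COc1cccc(OC)c1N1C(=O)CSC1c1cccc(C(=O)NCCCCc2ccccc2)c1` gives 80% and so holds the lowest of the three numbers; compound 1 is nearest, with a step of a number 9 percentage points lower from compound 1 to compound 3 (within the scatter), while compound 2 is furthest, with a step of a number 12 percentage points lower from compound 2 to compound 3 (beyond the scatter). Between compound 1 and compound 2 the step is a number 3 percentage points higher from compound 1 to compound 2 (within the scatter).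

Compound 4 `O=C(NCCCCc1ccccc1)c1cccc(C2SCC(=O)N2c2ccccc2F)c1` has not been measured. It differs from compound 3 in that (2-fluorophenyl in place of 2,6-dimethoxyphenyl on an amide-type nitrogen in a ring). Within the data shown here, the steps that bear on this change are the two into compound 3: the one from compound 1, which was within the scatter, and the one from compound 2, which was beyond it. Reversing the dimethoxyphenyl for an aryl ring that carries a fluorine is therefore expected to bring a step of about a number 10 percentage points higher from compound 3 to compound 4 (within the scatter) upward, back into the neighbourhood of compound 1 and compound 2. Compound 4 is estimated at 90%, with a likely range from 82% to 96%.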

Compound 4, a percentage reported as inhibition, at one concentration (the size of the read-out at that concentration, not a potency): 92%
Beside the measured number, compound 4's estimate is 2 percentage points below it, and the stated range covers the measured number.
By their numbers in this assay, from the lowest: compounds 3, 1, 2 and 4 (each within the scatter of the next, the first and the last beyond it).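

On the amide-type nitrogen in a ring, 2-fluorophenyl is accepted in this assay much as phenyl is, with a number 3 percentage points higher from compound 1 to compound 4 (within the scatter), and exchanging 3-fluorophenyl for 2-fluorophenyl gives no change at the digits printed from compound 2 to compound 4 (within the scatter), so these data do not separate the two fluorine placements. 2,6-Dimethoxyphenyl now sits apart from both fluorophenyl compounds, with a number 12 percentage points higher from compound 3 to compound 4 (beyond the scatter) alongside the step into compound 3 from 3-fluorophenyl, although compound 1 goes against a clean split, with a number 9 percentage points lower from compound 1 to compound 3 (within the scatter). No evidence in hand accounts for any of these steps.

Going by these compounds, whether a single methoxy group, as in 2-methoxyphenyl, would sit with the fluorophenyl compounds or with compound 3 remains open. So does the effect of an aminomethyl group or a carboxylic acid on this aryl ring.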